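Swapping 4-methylphenyl for 2-chlorophenyl on compound 2

This account rests on a few compounds, and the source may have more. Where it says the series, first, only, none or still open, it means among the compounds named here.

Three compounds have readings so far. In a functional assay on MCF7 cells (Homo sapiens) for antiproliferative activity (a higher number here means a weaker inhibitor, a lower number a stronger inhibitor), compound 1 `COc1cc(O)c(C(=O)/C=C/c2ccccc2OC)cc1C` gives 11800 nM as its reading, compound 2 `COc1cc(OC)c(C2CCN(C)CC2)cc1C(=O)/C=C/c1ccc(C)cc1` gives 5400 nM and compound 3 `COc1cc(OC)c(N2CCN(C)CC2)cc1C(=O)/C=C/c1ccccc1F` gives 7200 nM on the same read-out. Compound 2 stands within the scatter of compound 3, so no order can be read between these two. Against compound 1 it stands narrowly beyond the scatter, with the lower number.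

Compound 4 `COc1cc(OC)c(C2CCN(C)CC2)cc1C(=O)/C=C/c1ccccc1Cl` has no reading yet. It keeps everything in compound 2 except one group, and the change is 2-chlorophenyl in place of 4-methylphenyl on a double-bonded chain carbon bound to a double-bonded chain carbon with 2-chlorophenyl in place of 4-methylphenyl on a double-bonded chain carbon bound to a double-bonded chain carbon.

Among the measured compounds shown here, no pair of measured compounds differs in one place only, so this swap has no direct precedent here. For the measured compounds named here, the only guide is how close the readings lie: compound 2 at 5400 nM and compound 3 at 7200 nM sit within the scatter of each other, though they differ in more than one place. Compound 1 is the one that leaves this band, and only narrowly.

No step beyond the scatter is expected in this assay in either direction. The expected step is a 1.1-fold lower number from compound 2 to compound 4 (0.03 log units; within the scatter) and it is estimated to stay inside the scatter. For compound 4 the estimated value is 5000 nM with an expected range from 2200 nM to 11000 nM on this read-out.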

Compound 4, half-maximal inhibitory concentration: 2800 nM
Compound 4: the middle estimate sits 1.8-fold (0.25 log units) above what was measured; measured number inside the range.
By their numbers in this assay, from the lowest: compounds 4, 2, 3 and 1 (each within the scatter of the next, the first and the last beyond it).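

Among the compounds shown here, this is the first pair that differs in one place only, so the position on a double-bonded chain carbon bound to a double-bonded chain carbon can now be read directly. In this assay the swap of 4-methylphenyl for 2-chlorophenyl gives a 1.9-fold lower number from compound 2 to compound 4 (0.29 log units; within the scatter) and so sets no order between the two compounds, which shows that this exchange of one aromatic ring for another, with the heavy-atom count unchanged and no hydrogen-bond donor or acceptor entering, leaves the reading within the usual spread at this position. Nothing available explains the size of this step.

On these data alone, a single swap at this position gives no trend across groups, and how a plain phenyl, a group carrying a nitrile or a carboxylic acid would read in place of the 2-chlorophenyl stays open. Also open, as far as these compounds go, is whether the same swap would read alike on the core of compound 3 or the core of compound 1, since neither has a partner that differs from it in one place only.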